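Chain extension from ethyl to propyl in the series

A few compounds are considered here, and "the series" means these few. Any claim that something is new, unique, unknown or untested is made for them only; others in the source may bear on it.

Measured so far in a functional assay on MCF7 cells (Homo sapiens) for inhibition, read by MTT assay; a higher number here means a weaker inhibitor, a lower number a stronger inhibitor
- compound 1 `CN1C(=O)/C(=C2\Nc3ccccc3\C2=N/O)c2ccccc21` with 58600 nM
- compound 2 `CCN1C(=O)/C(=C2\Nc3ccccc3\C2=N/O)c2ccccc21` with 6720 nM

Compound 2 holds the lower of the two numbers and is the stronger inhibitor of the pair. The measured step is an 8.7-fold lower number from compound 1 to compound 2 (0.94 log units; beyond the scatter) and lies beyond the scatter.

Compound 3 `CCCN1C(=O)/C(=C2\Nc3ccccc3\C2=N/O)c2ccccc21` carries one change relative to compound 2, namely methyl in place of hydrogen on a saturated chain carbon, two bonds along the chain from an amide-type nitrogen in a ring as methyl in place of hydrogen on a saturated chain carbon, two bonds along the chain from an amide-type nitrogen in a ring. Ethyl thus becomes propyl.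

Among the measured compounds shown here, only one measured step bears on this change. It is the same replacement of hydrogen by methyl, made on a saturated chain carbon bound to that nitrogen. A single step shows no trend, and the series holds no measured chain longer than ethyl. A further fall in this assay is expected, but a smaller one, possibly not beyond the scatter. The estimated step is a 1.7-fold lower number from compound 2 to compound 3 (0.23 log units; within the scatter) and remains uncertain. For compound 3 the expected value is 4000 nM with an estimated range of 1500 nM to 12000 nM around it.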

Compound 3, half-maximal inhibitory concentration: 87600 nM
For compound 3 the middle estimate is 22-fold (1.34 log units) below the measured one; the whole stated range lies below it.
By their numbers in this assay, from the lowest: compound 2; then compounds 1 and 3 (each within the scatter of the next).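

In this assay this position does not reward chain growth in one direction: methyl in place of hydrogen on a saturated chain carbon, two bonds along the chain from an amide-type nitrogen in a ring, gives a 13-fold higher number from compound 2 to compound 3 (1.12 log units; beyond the scatter) and so runs opposite to the earlier methyl-for-hydrogen change, which gave an 8.7-fold lower number from compound 1 to compound 2 (0.94 log units; beyond the scatter) one carbon closer to that nitrogen. Among the compounds shown here, the same replacement therefore has an outcome that depends on where it is made along the chain, something the single earlier step could not show. The two ends of the short series also meet, with a 1.5-fold higher number from compound 1 to compound 3 (0.17 log units; within the scatter) as the net result of replacing hydrogen by ethyl, which leaves compound 2 as the strongest inhibitor of the three, with ethyl as the only chain here that stands apart from the others. No supporting measurement is available to account for this reversal.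

From the compounds shown here alone, whether butyl or a longer chain stays at the level of compound 3 or falls further away remains open. Also open, going by these compounds, is whether a branched isopropyl group, or a propyl chain ending in an amine or a hydroxyl, could keep the level of compound 2.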